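Azide in Place of Hydroxy on the Core of Compound 1

The compounds below may be only part of what the source reports. "The series", "measured", "known", "first", "only" and "open" are said of these compounds alone.

Compound 1 `OCc1cc2ccccc2nc1-c1ccccc1O`: 74000 nM
Compound 2 `Cc1ccc2nc(-c3ccccc3O)c(CO)cc2c1`: 12000 nM

In a functional assay on K562 cells (Homo sapiens) for cytotoxicity, read by MTT assay, with a stated time of 24 h (a higher number here means a weaker inhibitor, a lower number a stronger inhibitor), compound 1 gives 74000 nM, the highest of the two numbers; compound 2 gives 12000 nM. Among the measured compounds shown here, the only measured step, a 6.2-fold lower number from compound 1 to compound 2 (0.79 log units; beyond the scatter), concerns a methyl in place of hydrogen on an aromatic carbon. Compound 3 `[N-]=[N+]=NCc1cc2ccccc2nc1-c1ccccc1O` differs from compound 1 by azido in place of hydroxy on a saturated chain carbon bound to an aromatic carbon. For the measured compounds named here, no measured step touches this position, so the methyl step gives no guide. Compound 3 is therefore expected to stay near compound 1, with an expected step of a 1.2-fold lower number from compound 1 to compound 3 (0.09 log units; within the scatter). The estimate for compound 3 is 60000 nM, in a range from 20000 nM to 200000 nM.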

Compound 3, half-maximal inhibitory concentration: 11000 nM
The estimate for compound 3 lay 5.5-fold (0.74 log units) above the measured number; measured number below the stated range.
By their numbers in this assay, from the lowest: compounds 3 and 2 (each within the scatter of the next); then compound 1.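

In this assay the change of hydroxymethyl to azidomethyl on the core of compound 1 moves the number beyond the scatter (a 6.7-fold lower number from compound 1 to compound 3 (0.83 log units; beyond the scatter)). Among the compounds shown here, this shows that the position on a saturated chain carbon bound to an aromatic carbon, untouched by the earlier compounds, does respond to substitution. Nothing available explains this step.

Only hydroxy and azido are shown at this place, so the compounds leave open how an amine, a carboxylic acid or a longer chain there would read. They also leave open whether azido would give a similar step on the core of compound 2.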